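Notes on the anilino halogen change in this series

The source may hold more compounds than are shown below. What is called first, only, known or untested is meant among the compounds shown, and "the series" means these compounds.

Compound 2 `C=CC(=O)Nc1cccc(NC(=O)CSc2nc(Nc3ccc(Br)cc3)c3ccccc3n2)c1` gives 6280 nM in a functional assay on NCI-H1975 cells (Homo sapiens) for inhibition, read by MTT assay, with a stated time of 72 h; on this read-out higher numbers stand for weaker inhibition and lower numbers for stronger inhibition. Going by the values given here, that is the higher of the two numbers measured so far; its nearest neighbour is compound 1 `C=CC(=O)Nc1cccc(NC(=O)CSc2nc(Nc3ccc(F)cc3)c3ccccc3n2)c1`, which in this assay gives 4430 nM, and the gap between the two is within the scatter. Among the compounds with values here, the one measured step, a 1.4-fold higher number from compound 1 to compound 2 (0.15 log units; within the scatter), exchanges one halogen for another on the aromatic carbon and moves nothing beyond the scatter.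

Compound 3 `C=CC(=O)Nc1cccc(NC(=O)CSc2nc(Nc3ccc(Cl)cc3Cl)c3ccccc3n2)c1` is not yet measured. Its change from compound 2 is 2,4-dichlorophenyl in place of 4-bromophenyl on a nitrogen on an aromatic ring. Within the data shown here, the exchange of bromo for chloro within this change resembles the single measured step, which was flat; the second chlorine on the entering ring has no measured counterpart, so its effect is unknown. Among the measured compounds shown here, with only one small step to lean on, the expectation for compound 3 is no shift beyond the scatter in this assay, that is a 1.0-fold lower number from compound 2 to compound 3 (0.02 log units; within the scatter). Compound 3 is therefore estimated at 6000 nM, with a range of 2500 nM to 15000 nM widened to cover the second chlorine.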

Compound 3, half-maximal inhibitory concentration: 5990 nM
Compound 3: the middle estimate sits 1.0-fold (0.00 log units) above what was measured, and the stated range covers the measured number.
By their numbers in this assay, from the lowest: compounds 1, 3 and 2 (each within the scatter of the next).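

In this assay, the change from 4-bromophenyl to 2,4-dichlorophenyl on the nitrogen gives a 1.0-fold lower number from compound 2 to compound 3 (0.02 log units; within the scatter), and the same entering group set against 4-fluorophenyl gives a 1.4-fold higher number from compound 1 to compound 3 (0.13 log units; within the scatter). Until now this position had shown only one halogen exchanged for another, whereas these steps add a second chlorine and raise the group from 7 to 8 heavy atoms, and neither step leaves the scatter, so the three halogenated phenyl groups cannot be ranked on this read-out. No evidence on this flat result is available.

From the compounds shown here alone, all three groups at this position are halogenated phenyl rings, so it remains open whether the read-out would move with a methoxy group, an amine or a carboxylic acid on the ring, or with a saturated ring such as cyclohexyl in place of the phenyl. The rest of the structure is also identical across the three compounds, which leaves open how much the number depends on parts outside this position, for instance with a longer chain between the sulfur and the amide carbonyl.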